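Dropping the fluorine from a thioether-linked inhibitor

This account rests on a few compounds, and the source may have more. Where it says the series, first, only, none or still open, it means among the compounds named here.

Measured so far in an assay on isolated protein for inhibition of retinal dehydrogenase 2 (Homo sapiens); on this read-out higher numbers stand for weaker inhibition and lower numbers for stronger inhibition:
compound 1 `Cn1ncc2c(=O)n(-c3ccccc3)c(/C=C/c3cccc(F)c3)nc21` gives 440 nM
compound 2 `CC(Sc1nc2c(cnn2C)c(=O)n1-c1ccccc1)c1cccc(F)c1` gives 110 nM
compound 3 `COc1cccc(C(C)Sc2nc3c(cnn3C)c(=O)n2-c2ccccc2)c1` gives 108 nM

Among these three numbers compound 2 stands second highest. Its nearest neighbour is compound 3, reached by a step of a 1.0-fold lower number from compound 2 to compound 3 (0.01 log units; within the scatter) that stays within the scatter; its furthest is compound 1, whose higher value lies beyond the scatter, though compound 1 and compound 2 differ in more than one place and their two values alone are all that can be said of that pair.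

Compound 4 `C[C@@H](Sc1nc2c(cnn2C)c(=O)n1-c1ccccc1)c1ccccc1` has not yet been measured in this assay. Against compound 2 the change is 1-phenylethyl in place of 1-(3-fluorophenyl)ethyl on a sulfur, so the fluorine leaves the aromatic ring and the substituent on the sulfur now carries a defined stereocentre. Within the data shown here, the only measured step that bears on it is the one from compound 2 to compound 3, where methoxy in place of fluoro on an aromatic carbon moved the number by a 1.0-fold lower number from compound 2 to compound 3 (0.01 log units; within the scatter), within the scatter. On that basis the expected step from compound 2 to compound 4 in this assay is no change at the digits printed from compound 2 to compound 4 (within the scatter), no change beyond the scatter in either direction. Compound 4 is therefore estimated at 110 nM, in the range 45 nM to 270 nM.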

Compound 4, half-maximal inhibitory concentration: 40 nM
Compound 4: the middle estimate sits 2.8-fold (0.44 log units) above what was measured, outside the stated range (below it).
By their numbers in this assay, from the lowest: compound 4; then compounds 3 and 2 (each within the scatter of the next); then compound 1.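

In this assay the substituent on the sulfur proves sensitive to change: putting 1-phenylethyl in place of 1-(3-fluorophenyl)ethyl gives a 2.8-fold lower number from compound 2 to compound 4 (0.44 log units; beyond the scatter) and so moves the number beyond the scatter, whereas methoxy in place of fluoro had given only a 1.0-fold lower number from compound 2 to compound 3 (0.01 log units; within the scatter) and stayed within it. The earlier pair therefore gave no sign that this substituent could shift the number at all, but this step joins two changes, since the fluorine leaves and the substituent now carries a defined stereocentre, and the compounds shown cannot divide the shift between them. Nothing available accounts for the lower number in compound 4.

Open, on these data alone, is whether the mirror-image form of compound 4, or a mixture of both forms, would stand with compound 4 or with compound 2, which would show how much of the step belongs to the stereocentre. Also open, as far as these compounds go, is how the number would respond to a chloro or hydroxyl group on the aromatic ring, or to a longer chain such as 1-phenylpropyl on the sulfur.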